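The compounds below may be only part of what the source reports. "The series", "measured", "known", "first", "only" and "open" are said of these compounds alone.

Measured so far:
compound 1 `Oc1ccccc1-c1cc(-c2cccc(F)c2)cc(-c2ccccc2O)n1`: > 50000 nM
compound 2 `Oc1cccc(-c2cc(-c3ccccc3F)cc(-c3ccccc3O)n2)c1`: 24200 nM

In a functional assay on T47D cells (Homo sapiens) for inhibition (on this read-out higher numbers stand for weaker inhibition and lower numbers for stronger inhibition), compound 2 gives the only result that is a true number. Compound 1 sits at the limit of > 50000 nM in this assay, at which 1 of the 2 values shown sits, which is a limit of the assay rather than a number. Compound 3 `Oc1cccc(-c2cc(-c3cccc(F)c3)cc(-c3ccccc3O)n2)c1` differs from compound 2 by one change: 3-fluorophenyl in place of 2-fluorophenyl on an aromatic carbon. Among the measured compounds shown here, no measured pair shows this change, so only a small step, if any, is expected. Compound 3 is expected to give about 30000 nM, within the range 12000 nM to 80000 nM. The step of a 1.2-fold higher number from compound 2 to compound 3 (0.09 log units; within the scatter) is expected to stay within the usual scatter.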

Compound 3, half-maximal inhibitory concentration: > 50000 nM
Compound 3: only a limit was reported; the forecaster's own chance of this, stated with the estimate: 35%; at least 1.6-fold (0.22 log units) between middle value and limit.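

Swapping 2-fluorophenyl for 3-fluorophenyl, two groups with the same atoms, gives an at least 2.0-fold higher number from compound 2 to compound 3 (0.31 log units; beyond the scatter), so in this assay this position responds to where the fluorine sits on the ring and the change weakens inhibition. Compound 3 gives a limit, not a number, and the step linking it to compound 1 cannot be read, because both stand at a limit: the limit of > 50000 nM in this assay, at which 2 of the 3 values shown sit.

Still open, as far as these compounds go, is how far inhibition falls with 3-fluorophenyl. From the compounds shown here alone, it is also open whether an amine or a carboxylic acid in place of the fluorine would give stronger inhibition than compound 2 shows.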